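A few compounds are considered here, and "the series" means these few. Any claim that something is new, unique, unknown or untested is made for them only; others in the source may bear on it.

Compound 1 `O=C(/C=C/c1ccc(OCc2cn(Cc3ccc(F)cc3)nn2)cc1)c1ccc(Br)cc1`: 22%
Compound 2 `COc1ccc(C(=O)/C=C/c2ccc(OCc3cn(Cc4ccc(Br)cc4)nn3)cc2)cc1`: 59%

Both numbers come from a functional assay on HepG2 cells (Homo sapiens) for inhibition, read by MTT assay, with a stated time of 48 h, tested at 10 uM; a lower number here means less inhibition of growth, a higher number more inhibition of growth at the concentration tested. Compound 2 stands highest of the two, and compound 1 sits well below it, beyond the usual scatter. These two differ in more than one place, so no single change can be credited for the gap. Compound 3 `COc1ccc(C(=O)/C=C/c2ccc(OCc3cn(Cc4ccc(F)cc4)nn3)cc2)cc1` keeps the core of compound 2 and carries fluoro in place of bromo on an aromatic carbon. Among the measured compounds shown here, no measured pair shows this exchange on its own, so a modest drop in this assay seems the likeliest outcome, though a step within the scatter is also possible. The estimated step is a number 14 percentage points lower from compound 2 to compound 3 (beyond the scatter). Compound 3 is expected to give 45%, within 25% to 65%.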

Compound 3, percent growth inhibition at one concentration: 21%
Estimate against measurement, compound 3: 24 percentage points above; the measured number lies below the stated range.
By their numbers in this assay, from the lowest: compounds 3 and 1 (each within the scatter of the next); then compound 2.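

In this assay, fluoro in place of bromo on the benzyl group gives a number 38 percentage points lower from compound 2 to compound 3 (beyond the scatter), so in this pair the bromo on that group carries a large part of the growth inhibition. With the 4-fluorobenzyl group kept, a methoxy group taking over from the bromo gives a number 1 percentage points lower from compound 1 to compound 3 (within the scatter), a step that separates nothing beyond the scatter. Nothing measured here explains the large step. On these data alone, whether chloro or an amine on the benzyl group would hold the number of compound 2 stays open.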